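Exchanging the Halogenated Ring and Watching Cell Tolerance

The source may report more compounds than this note shows. Statements on the series, on what has been measured and on what is new or still open speak of the compounds shown alone.

Three compounds share one core. Compound 3 `N#Cc1ccc(Nc2nccc(OCc3cccc(Br)c3)n2)cc1` gives 221000 nM in an ADME assay on MT4 cells (Homo sapiens) for cytotoxicity, read by MTT assay, with a stated time of 5 days; a higher number here means that more compound is tolerated, a lower number that less compound is tolerated. Compound 1 `N#Cc1ccc(Nc2nccc(OCc3ccccc3Cl)n2)cc1` gives 146000 nM in this assay, and compound 2 `N#Cc1ccc(Nc2nccc(NCc3ccccn3)n2)cc1` gives 8500 nM. Compound 3 thus holds the highest of the three numbers; its gap to compound 1 lies within the scatter, while compound 2 sits far below it. Compound 4 `N#Cc1ccc(Nc2nccc(OCc3cc(F)ccc3Br)n2)cc1` has not yet been measured; it differs from compound 3 by 2-bromo-5-fluorophenyl in place of 3-bromophenyl on a saturated chain carbon bound to an oxygen on an aromatic ring. Among the compounds with values here, the one measured step that bears on such a change is a 1.5-fold higher number from compound 1 to compound 3 (0.18 log units; within the scatter), where the ring on the saturated chain carbon was exchanged and the number hardly moved. The expected step is therefore a 1.1-fold lower number from compound 3 to compound 4 (0.04 log units; within the scatter), nothing beyond the scatter. Compound 4 is estimated at 200000 nM, between 80000 nM and 450000 nM.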

Compound 4, half-maximal cytotoxic concentration: 190000 nM
For compound 4 the middle estimate is 1.1-fold (0.02 log units) above the measured one; low and high end bracket the measured number.
By their numbers in this assay, from the lowest: compound 2; then compounds 1, 4 and 3 (each within the scatter of the next).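

In this assay the 2-bromo-5-fluorophenyl group gives a 1.2-fold lower number from compound 3 to compound 4 (0.07 log units; within the scatter) and a 1.3-fold higher number from compound 1 to compound 4 (0.11 log units; within the scatter) at this same place. Within the data shown here, this position has now taken three differently halogenated phenyl groups, and no step among them leaves the scatter, so they cannot be ranked. Nothing measured here explains this tolerance. The compounds shown carry only halogens on this phenyl group. On these data alone, whether an amine or a carboxylic acid on the ring, or a longer chain at this place, would leave the number as steady remains open.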